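The source may report more compounds than this note shows. Statements on the series, on what has been measured and on what is new or still open speak of the compounds shown alone.

The series shares one core, seen in compound 1 `Cc1ccccc1C(=O)Nc1ccc(S(=O)(=O)NC2CCN(C(=O)CO)CC2)c2ccccc12`, in which the sulfonamide nitrogen carries a ring whose amide substituent is varied. In an assay on L1.2 cells for binding affinity to C-C chemokine receptor type 8 (Homo sapiens) (on this read-out lower numbers stand for stronger inhibition and higher numbers for weaker inhibition), compound 1 gives 5.4 nM. Compound 2 `Cc1ccccc1C(=O)Nc1ccc(S(=O)(=O)NC2CCN(C(=O)CCCN)CC2)c2ccccc12` gives 1.6 nM in this assay, and compound 3 `Cc1ccccc1C(=O)Nc1ccc(S(=O)(=O)NC2CCN(C(=O)N3CCOCC3)CC2)c2ccccc12` gives 6.3 nM. Compound 2 stands at the lowest number of the three: a 3.4-fold lower number from compound 1 to compound 2 (0.53 log units; beyond the scatter), while a 1.2-fold higher number from compound 1 to compound 3 (0.07 log units; within the scatter), and a 3.9-fold higher number from compound 2 to compound 3 (0.60 log units; beyond the scatter). Both steps that lead to or away from compound 2 are beyond the scatter, so on these numbers it is the most potent of the three.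

Compound 4 `CCCC(=O)N1CCC(NS(=O)(=O)c2ccc(NC(=O)c3ccccc3C)c3ccccc23)C1` has not been measured. Relative to compound 2 the change is 1-(propylcarbonyl)pyrrolidin-3-yl in place of 1-((3-aminopropyl)carbonyl)piperidin-4-yl on a sulfonamide nitrogen. Among the compounds with values here, two measured steps bear on it: replacing the amine-bearing chain of compound 2 with a morpholine amide raised the number modestly, and the step from the hydroxy compound to the amine lowered it by a similar amount. Within the data shown here, compound 4 likewise lacks the terminal amine; the change of ring size has no precedent among the measured compounds and cannot be weighed. The expectation for compound 4 is therefore a modest rise in this assay, a 3.8-fold higher number from compound 2 to compound 4 (0.57 log units; beyond the scatter). Compound 4 is estimated at 6 nM, with a range from 2 nM to 20 nM.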

Compound 4, inhibition constant: 34.3 nM
For compound 4 the middle estimate is 5.7-fold (0.76 log units) below the measured one; the whole stated range lies below it.
By their numbers in this assay, from the lowest: compound 2; then compounds 1 and 3 (each within the scatter of the next); then compound 4.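

Within the data shown here, the replacement of 1-((3-aminopropyl)carbonyl)piperidin-4-yl by 1-(propylcarbonyl)pyrrolidin-3-yl on the sulfonamide nitrogen gives a 21-fold higher number from compound 2 to compound 4 (1.33 log units; beyond the scatter), the largest step so far and the first rated large. The hydroxy-bearing compound 1 has no terminal amine either, yet the same ring change with its own chain change still gives a 6.4-fold higher number from compound 1 to compound 4 (0.80 log units; beyond the scatter), so in this assay the step from compound 2 is not matched by the earlier amine-free comparison, where compound 1 and compound 3 differ only within the scatter. Both new steps alter the ring and the chain at once, and no measurement shown here explains their size.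

The share of each step belonging to the ring and to the chain stays unresolved: 1-(propylcarbonyl)piperidin-4-yl would isolate the chain change from compound 2, while 1-((3-aminopropyl)carbonyl)pyrrolidin-3-yl would isolate the ring change. Also open is how a carboxylic acid or a longer chain ending in an amine would read on the piperidin-4-yl amide, since the only amine-bearing chain shown is the 3-aminopropyl of compound 2.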